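Thiophen-2-yl to 4-methoxyphenoxy: cytotoxicity notes on the series

The source may hold more compounds than are shown below. What is called first, only, known or untested is meant among the compounds shown, and "the series" means these compounds.

For the measured compounds named here, in an ADME assay on cells (Homo sapiens) for cytotoxicity, read by resazurin assay, with a stated time of 5 days (on this read-out higher numbers stand for lower toxicity in this test and lower numbers for higher toxicity in this test), compound 1 (`O=S(=O)(Cc1nc(-c2ccc(Cl)nc2)c2sccc2n1)c1cccc(Cl)c1`) gives 70000 nM as the only true number so far. Compound 2 (`O=S(=O)(Cc1nc(-c2cccnc2)c2sccc2n1)c1cccc(Cl)c1`) reads > 50000 nM as a limit of the assay. Compound 3 (`O=S(=O)(Cc1nc(-c2cccs2)c2sccc2n1)c1cccc(Cl)c1`) reads > 50000 nM as a limit too, so it stands without a number of its own. The overall picture is (the limit of > 50000 nM in this assay, at which 2 of the 3 values shown sit) for now.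

Compound 4 (`COc1ccc(Oc2nc(CS(=O)(=O)c3cccc(Cl)c3)nc3ccsc23)cc1`) carries 4-methoxyphenoxy in place of thiophen-2-yl on an aromatic carbon. The changes at that same carbon give no size: there is a step that the limit leaves unreadable from compound 1 to compound 3 and there is a step that the two limits leave unreadable from compound 2 to compound 3 so neither sets a direction. The chloro change gives none either, being a step that the limit leaves unreadable from compound 1 to compound 2 in the same way.

Going by the values given here, the only anchor is compound 1 at 70000 nM in this assay so no step beyond the scatter is expected. The expected step is an at least 1.1-fold lower number from compound 3 to compound 4 (0.04 log units; that floor lies within the scatter) in size, with no direction favoured. Compound 4 is estimated at 45000 nM with a range from 15000 nM to 90000 nM and may well come back as a limit.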

Compound 4, half-maximal cytotoxic concentration: > 50000 nM
Compound 4 ended at the assay's limit; the forecaster's own chance of this, stated with the estimate: 55%; middle value at least 1.1-fold (0.04 log units) away from the limit.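

For the compounds shown here, compound 4 is a limit of the assay, so no step linking it to compound 1, compound 2 or compound 3 can be read in this assay, and the values gather at one point: the limit of > 50000 nM in this assay, at which 3 of the 4 values shown sit. As far as these compounds go, what stays open is whether any group at this aromatic carbon moves the read-out, and how far compound 2, compound 3 and compound 4 truly lie from compound 1.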